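From Furan to Fluorophenyl: Expecting a Weaker Inhibitor

The source may hold more compounds than are shown below. What is called first, only, known or untested is meant among the compounds shown, and "the series" means these compounds.

Of the compounds shown here, three sharing one core have been measured in an assay on cells for inhibition of histone deacetylase 4 (Homo sapiens), read by fluorescence, with a stated time of 30 min; a lower number here means a stronger inhibitor, a higher number a weaker inhibitor. Compound 1 `O=C1NC(=O)/C(=C\c2ccc(OCC(=O)N3N=C(c4ccccc4)CC3c3ccc(F)cc3)cc2)S1` gives 1700 nM, compound 2 `O=C1NC(=O)/C(=C\c2ccc(OCC(=O)N3N=C(c4ccc(F)cc4)CC3c3ccccc3)cc2)S1` gives 4200 nM, and compound 3 `O=C1NC(=O)/C(=C\c2ccc(OCC(=O)N3N=C(c4ccc(F)cc4)CC3c3ccco3)cc2)S1` gives 880 nM. Compound 3 therefore has the lowest number of the three; its gap to compound 1 lies within the scatter, while its gap to compound 2 lies beyond it, as the step of a 4.8-fold lower number from compound 2 to compound 3 (0.68 log units; beyond the scatter) shows.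

Compound 4 `O=C1NC(=O)/C(=C\c2ccc(OCC(=O)N3N=C(c4ccc(F)cc4)CC3c3ccc(F)cc3)cc2)S1` has not yet been measured. It differs from compound 3 in one place: 4-fluorophenyl in place of furan-2-yl on a saturated ring carbon. Going by the values given here, the only measured step at this position, a 4.8-fold lower number from compound 2 to compound 3 (0.68 log units; beyond the scatter), runs the other way, from phenyl to furan-2-yl, and lowered the number. Among the compounds with values here, compound 1 and compound 2 both carry a six-membered carbon ring on that saturated ring carbon and both sit above compound 3, though no single step links either of them to compound 4. Taken together, these numbers lead one to expect that removing the furan-2-yl again will raise the number, and the estimated step of a 2.8-fold higher number from compound 3 to compound 4 (0.45 log units; beyond the scatter) is a modest rise, beyond the scatter. Compound 4 is accordingly expected to give about 2500 nM in this assay, with a likely range from 1000 nM to 6000 nM.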

Compound 4, half-maximal inhibitory concentration: 1400 nM
Beside the measured number, compound 4's estimate is 1.8-fold (0.25 log units) above it, within the range that was stated.
By their numbers in this assay, from the lowest: compounds 3, 4 and 1 (each within the scatter of the next); then compound 2.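

Going by these compounds alone, at the saturated ring carbon in this assay, a 1.6-fold higher number from compound 3 to compound 4 (0.20 log units; within the scatter) shows that the furan-2-yl is not the only group compatible with a number in this range, since 4-fluorophenyl, with its six-membered aromatic ring of carbon only, can stand in its place without a change beyond the scatter. The fluoro steps show that the earlier gap at this position depended on the phenyl ring lacking fluoro: adding fluoro to the phenyl on the saturated ring carbon gives a 3.0-fold lower number from compound 2 to compound 4 (0.48 log units; beyond the scatter), while adding it to the phenyl on the other ring atom that bears a large group gives only a 1.2-fold lower number from compound 1 to compound 4 (0.08 log units; within the scatter). No evidence is available to explain these differences.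

The compounds shown leave open whether the saturated ring carbon accepts groups of another kind, such as a thiophene, a pyridine, a cyclohexyl ring or a longer alkyl chain. They also leave open how an amine or a carboxylic acid on the phenyl ring at this carbon would compare with the fluoro.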